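Series notes: the step from compound 3 to compound 4

A few compounds are considered here, and "the series" means these few. Any claim that something is new, unique, unknown or untested is made for them only; others in the source may bear on it.

Measured so far:
compound 1 `Cc1ccc(NC(=O)N[C@H](C)c2ccccc2)cc1`: 98%
compound 2 `C[C@@H](NC(=O)Nc1ccccc1F)c1ccccc1`: 95%
compound 3 `C[C@@H](NC(=O)Nc1ccc(F)cc1F)c1ccccc1`: 100%

All three values come from an ADME assay on the whole organism with Oryza sativa as the target, tested at 1 uM; a higher number here means a weaker effect of the compound at the concentration tested, a lower number a stronger effect. Compound 3 stands at the top of the three numbers, but its distances to compound 1 and to compound 2 are both within the usual scatter, so no order among the three can be read from them. The one measured step that joins two of these compounds, a number 5 percentage points higher from compound 2 to compound 3 (within the scatter), is also within the scatter; it adds a fluoro group and leaves the read-out essentially unchanged.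

Compound 4 `Cc1ccc(NC(=O)N[C@H](C)c2ccccc2)c(F)c1` is not yet measured. It differs from compound 3 in one place:
methyl in place of fluoro on an aromatic carbon

Going by the values given here, no measured step removes a fluoro group or introduces a methyl group on an aromatic carbon, so nothing bears directly on this change. What the data do show is that one change on the same ring, the fluoro step from compound 2 to compound 3, stayed within the scatter, and that all three measured values lie close together near the top of the scale. On that basis the step of a number 3 percentage points lower from compound 3 to compound 4 (within the scatter) is expected to stay within the scatter, with no direction beyond it. Compound 4 is therefore estimated at 97%, with a range from 88% to 100%.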

Compound 4, a percentage reported as activity, at one concentration (the size of the read-out at that concentration, not a potency): 99%
The estimate for compound 4 lay 2 percentage points below the measured number; the range from low to high includes it.
By their numbers in this assay, from the lowest: compounds 2, 1, 4 and 3 (each within the scatter of the next).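

In this assay, methyl in place of fluoro on an aromatic carbon, para to a large group, gives a number 1 percentage points lower from compound 3 to compound 4 (within the scatter), so at this position the swap between the two groups does not move the read-out beyond the scatter. The same position can now also be read for methyl in place of hydrogen, which gives a number 4 percentage points higher from compound 2 to compound 4 (within the scatter), so hydrogen, fluoro and methyl at this position cannot be told apart in this assay. Fluoro in place of hydrogen also gives a number 1 percentage points higher from compound 1 to compound 4 (within the scatter), so the earlier fluoro step no longer stands alone and the change stays within the scatter on a second core: the same change on two cores in this assay, a number 5 percentage points higher (within the scatter) from compound 2 to compound 3 and a number 1 percentage points higher (within the scatter) from compound 1 to compound 4, 4 percentage points apart, within the scatter of two such steps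

The compounds shown leave open whether any group at this position can shift the read-out beyond the scatter, for example an amine, a carboxylic acid or a longer chain such as propyl. They also leave open whether a change elsewhere on the shared core would do so, since every step shown so far lies on the same ring and stays within the scatter.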